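Resolving the stereocentre in a biaryl imidazolyl carbinol series

The compounds below may be only part of what the source reports. "The series", "measured", "known", "first", "only" and "open" are said of these compounds alone.

Compound 1 `CC(C)C(O)(c1cccc(-c2ccc(F)cc2)c1)c1c[nH]cn1` and compound 2 `CC(=O)Nc1cccc(-c2ccc(C(O)(c3c[nH]cn3)C(C)C)cc2)c1` share the same core and are both measured in an assay on isolated protein for inhibition of steroid 17-alpha-hydroxylase/17,20 lyase (Homo sapiens); a lower number here means a stronger inhibitor, a higher number a weaker inhibitor. In this assay compound 1 gives 19 nM, and compound 2 gives 24 nM, the higher of the two numbers, with the gap to compound 1 lying within the scatter, so no order between them can be read.

Compound 3 `CC(=O)Nc1cccc(-c2ccc([C@@](O)(c3c[nH]cn3)C(C)C)cc2)c1` is the next member. It differs from compound 2 in this way: the two compounds have the same atoms and bonds; at least one stereo element is drawn with a configuration in one of them and without one in the other: 1 of 1 stereo elements differ; a stereocentre at a saturated chain carbon is drawn without a configuration in compound 2 and R in compound 3. For the measured compounds named here, no step between measured compounds covers a change of this kind, so the expectation rests on the drawn configuration alone. Compound 3 is expected to sit at 14 nM, within 5 nM to 60 nM, in this assay. The step from compound 2 to compound 3 is estimated at a 1.7-fold lower number from compound 2 to compound 3 (0.23 log units; within the scatter), which would place compound 3 close to compound 2 or somewhat lower, with a wide range because the single drawn configuration may also carry less of the activity than the undrawn mixture of compound 2 at 24 nM.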

Compound 3, half-maximal inhibitory concentration: 340 nM
For compound 3 the middle estimate is 24-fold (1.39 log units) below the measured one, and the stated range ends below it.
By their numbers in this assay, from the lowest: compounds 1 and 2 (each within the scatter of the next); then compound 3.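

With atoms and bonds unchanged, this assay still separates the two compounds, with a 14-fold higher number from compound 2 to compound 3 (1.15 log units; beyond the scatter). For the compounds shown here, the earlier compounds gave no reading on the stereocentre at a saturated chain carbon, and this is the first sign that its drawn configuration is not neutral, with R on the weaker side of the undrawn form. The only difference to which this step can be tied is: the fact that one of compounds 2 and 3 is drawn with a defined configuration and the other without, at the place where they differ

If compound 2 is a mixture of configurations, most of its activity would lie outside the R form, but the compounds shown do not settle its composition or what the opposite configuration gives. Also open, going by these compounds, is whether the same gap between configurations would persist with a methyl ether in place of the hydroxyl, or with a longer chain at the stereocentre.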